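The source may report more compounds than this note shows. Statements on the series, on what has been measured and on what is new or still open speak of the compounds shown alone.

Measured so far in a functional assay on U-251 cells (Homo sapiens); on this read-out lower numbers stand for stronger inhibition of growth and higher numbers for weaker inhibition of growth:
- compound 1 `O=S(=O)(/C=C/c1ccc(Cl)cc1Cl)Cc1ccc(Nc2ncnc3ccccc23)cc1`: 4000 nM
- compound 2 `O=S(=O)(/C=C/c1ccc(Cl)cc1Cl)Cc1ccc(Nc2ncnc3cc(Cl)ccc23)cc1`: 53000 nM

Of the two measured compounds, compound 2 at 53000 nM has the higher number, so it is the weaker growth inhibitor in this assay. Going by the values given here, the only measured step is a 13-fold higher number from compound 1 to compound 2 (1.12 log units; beyond the scatter), for chloro in place of hydrogen on an aromatic carbon of the shared core.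

Next in the series is compound 3 `O=S(=O)(/C=C/c1ccc(F)cc1F)Cc1ccc(Nc2ncnc3cc(Cl)ccc23)cc1`, which keeps that chloro and changes the other end of the molecule: 2,4-difluorophenyl in place of 2,4-dichlorophenyl on a double-bonded chain carbon bound to a double-bonded chain carbon. In words, this is 2,4-difluorophenyl in place of 2,4-dichlorophenyl on a double-bonded chain carbon bound to a double-bonded chain carbon.

Among the compounds with values here, no measured step covers this place. The large step of a 13-fold higher number from compound 1 to compound 2 (1.12 log units; beyond the scatter) shows that a single substitution can move this read-out strongly, but it sets neither the size nor the direction here. The expected change is therefore small, leaning slightly to the lower side, and is not firmly beyond the scatter: a 1.8-fold lower number from compound 2 to compound 3 (0.25 log units; within the scatter). The estimated value for compound 3 is 30000 nM, with an expected range of 9000 nM to 80000 nM.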

Compound 3, concentration for 50% growth inhibition: > 100000 nM
Compound 3 ended at the assay's limit (the forecaster's own chance of this, stated with the estimate: 15%); middle value at least 3.3-fold (0.52 log units) away from the limit.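

In this assay compound 3 gives > 100000 nM and this is a limit of the assay, not a number. The change from 2,4-dichlorophenyl to 2,4-difluorophenyl on a double-bonded chain carbon bound to a double-bonded chain carbon can therefore be read only as a floor (an at least 1.8-fold higher number from compound 2 to compound 3 (0.27 log units; that floor lies within the scatter)), so it is not shown to lie beyond the scatter, although its true size may be larger. Going by these compounds alone, this is the first reading at this end of the molecule, and with the chloro on the shared core kept, 2,4-difluorophenyl gives no lower number than 2,4-dichlorophenyl and so does not win back the growth inhibition lost in the earlier step (a 13-fold higher number from compound 1 to compound 2 (1.12 log units; beyond the scatter)).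

The compounds shown leave open how large the change to 2,4-difluorophenyl really is, and whether it acts in the same way on the core of compound 1, which lacks the chloro. They also leave open whether an amine or a methoxy group on the phenyl ring, in place of the halogens, would bring the number down at this position.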